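Adding a methoxy group to compound 3

The source may report more compounds than this note shows. Statements on the series, on what has been measured and on what is new or still open speak of the compounds shown alone.

Compound 1 `CCCCOC(=O)c1cc(CC)sc1NC(=O)c1ccc([N+](=O)[O-])o1`: > 20000 nM
Compound 2 `O=C(Nc1cccs1)c1ccc([N+](=O)[O-])o1`: > 20000 nM
Compound 3 `O=C(Nc1ccccc1)c1ccc([N+](=O)[O-])o1`: > 20000 nM

In an ADME assay on HeLa cells (Homo sapiens) for cytotoxicity, read by resazurin assay, with a stated time of 65 h (a higher number here means that more compound is needed for the effect, a lower number that less compound is needed), compound 3 gives > 20000 nM, and this is a limit, not a number. The measured compounds all tell the same story: the limit of > 20000 nM in this assay, at which 3 of the 3 values shown sit. Compound 4 `COc1cccc(NC(=O)c2ccc([N+](=O)[O-])o2)c1` differs from compound 3 by one change, methoxy in place of hydrogen on an aromatic carbon. Within the data shown here, no measured pair shows what such a change does, so no step beyond the usual scatter is expected in this assay. The expected step is a number no higher from compound 3 to compound 4 (the limit leaves the size open). A result reported only as a limit is the likeliest outcome. For compound 4 the estimated value is 20000 nM, with an expected range from 9000 nM to 40000 nM.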

Compound 4, half-maximal effective concentration: > 20000 nM
Compound 4 gave a limit, no number (the forecaster's own chance of this, stated with the estimate: 75%); the middle value lies on the limit itself.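

Among these compounds, compound 3 and compound 4 are both reported only as limits, not numbers, so no step between them can be read. The compounds shown leave open whether methoxy in place of hydrogen on an aromatic carbon changes the result at all, and what concentration any of them would need for an effect.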